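The source may hold more compounds than are shown below. What is called first, only, known or untested is meant among the compounds shown, and "the series" means these compounds.

Compound 3 `COc1ccccc1NC1=CC(=O)c2c(nc3n2[C@H]2OC[C@@H](O)[C@H]2OC3)C1=O` gives 1670 nM in a functional assay on MGC-803 cells (Homo sapiens) for inhibition, read by sulforhodamine B assay; on this read-out higher numbers stand for weaker inhibition and lower numbers for stronger inhibition. Of the two numbers measured, its value and that of compound 1 `COc1cccc(NC2=CC(=O)c3c(nc4n3[C@H]3OC[C@@H](O)[C@H]3OC4)C2=O)c1`, which gives 1790 nM, sit together, and the step of a 1.1-fold lower number from compound 1 to compound 3 (0.03 log units; within the scatter) lies within the scatter. Compound 2 `O=C1C(N2CCCCC2)=CC(=O)c2c1nc1n2[C@H]2OC[C@@H](O)[C@H]2OC1` reaches only a limit of the assay, > 4000 nM. The steps of an at least 2.2-fold higher number from compound 1 to compound 2 (0.34 log units; beyond the scatter) and an at least 2.3-fold lower number from compound 2 to compound 3 (0.37 log units; beyond the scatter) show that the measured differences so far arise when piperidin-1-yl and an arylamino group trade places on the double-bonded ring carbon. Compound 4 `O=C1C(Nc2ccc(C(F)(F)F)cc2)=CC(=O)c2c1nc1n2[C@H]2OC[C@@H](O)[C@H]2OC1` keeps the arylamino group and differs from compound 3 by 4-(trifluoromethyl)phenyl in place of 2-methoxyphenyl on an amine nitrogen. For the measured compounds named here, the only measured step that exchanges one aryl group for another on the amine nitrogen, a 1.1-fold lower number from compound 1 to compound 3 (0.03 log units; within the scatter), stayed within the scatter, so a move from 2-methoxyphenyl to 4-(trifluoromethyl)phenyl is expected to bring at most a small change in this assay. For compound 4 the estimate is 1800 nM, spanning 800 nM to 4000 nM, which means an expected step of a 1.1-fold higher number from compound 3 to compound 4 (0.03 log units; within the scatter).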

Compound 4, half-maximal inhibitory concentration: 1860 nM
Estimate against measurement, compound 4: 1.0-fold (0.01 log units) below; low and high end bracket the measured number.
By their numbers in this assay, from the lowest: compounds 3, 1 and 4 (each within the scatter of the next). At a limit, above all of these: compound 2.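

In this assay, both new steps, a 1.1-fold higher number from compound 3 to compound 4 (0.05 log units; within the scatter) and a 1.0-fold higher number from compound 1 to compound 4 (0.02 log units; within the scatter), stay within the scatter. For the compounds shown here, until now, the only aryl exchange on this amine nitrogen was between two methoxyphenyl groups; with 4-(trifluoromethyl)phenyl, which carries fluorine and no oxygen, compound 1, compound 3 and compound 4 still sit together, so the flat result is not confined to methoxyphenyl groups. No measurement given here bears on why these aryl groups give matching numbers.

Going by these compounds, the value of compound 2, > 4000 nM, is a limit of the assay, so the size of its gap from the arylamino compounds stays open. Also open, on these data alone, is whether a carboxylic acid or an amine on the aryl ring, or a benzyl group on this nitrogen, would move the number in this assay beyond the scatter.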